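Fluoro for nitro on the aryl group of compound 1

The source may report more compounds than this note shows. Statements on the series, on what has been measured and on what is new or still open speak of the compounds shown alone.

Compound 1 `Cn1nnnc1SCC(=O)N/N=c1/scc(-c2ccc([N+](=O)[O-])cc2)n1-c1ccccc1` is a hydrazone whose tetrazole carries a methyl on its aromatic nitrogen. In an ADME assay on NIH3T3 cells (Mus musculus) for cytotoxicity, read by MTT assay, with a stated time of 24 h (a higher number here means a weaker inhibitor, a lower number a stronger inhibitor), compound 1 gives 167 ug/mL, the highest of the two numbers measured. Among the compounds with values here, its only measured neighbour is compound 2 `O=C(CSc1nnnn1-c1ccccc1)N/N=c1/scc(-c2ccc([N+](=O)[O-])cc2)n1-c1ccccc1`, which in this assay gives 14.3 ug/mL, a step of a 12-fold lower number from compound 1 to compound 2 (1.07 log units; beyond the scatter) for phenyl in place of methyl on an aromatic nitrogen. Compound 3 `Cn1nnnc1SCC(=O)N/N=c1/scc(-c2ccc(F)cc2)n1-c1ccccc1` differs from compound 1 elsewhere: fluoro in place of nitro on an aromatic carbon. Within the data shown here, no measured step touches this part of the molecule, so the one step that exists, on the tetrazole, gives no guide to the size or direction of the change. For compound 3 the expected step is therefore a 1.1-fold lower number from compound 1 to compound 3 (0.05 log units; within the scatter), a number close to that of compound 1, with a wide range. Compound 3 is estimated at 150 ug/mL, between 50 ug/mL and 450 ug/mL.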

Compound 3, half-maximal inhibitory concentration: 113 ug/mL
Estimate against measurement, compound 3: 1.3-fold (0.12 log units) above; the measured number falls inside the stated range.
By their numbers in this assay, from the lowest: compound 2; then compounds 3 and 1 (each within the scatter of the next).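

Within the data shown here, the first measured change on this aryl group, 4-nitrophenyl to 4-fluorophenyl, gives a 1.5-fold lower number from compound 1 to compound 3 (0.17 log units; within the scatter) in this assay and so stays inside the usual scatter. At this aromatic carbon, para to a large group, nitro with its three heavy atoms can thus give way to the single heavy atom of fluoro with no change that can be read, whereas the phenyl for methyl swap on the aromatic nitrogen gives a 12-fold lower number from compound 1 to compound 2 (1.07 log units; beyond the scatter) in the same assay. No supporting measurement is available to explain either result.

Going by these compounds, whether this position stays as quiet for other groups remains open, since an amine, a carboxylic acid or a methoxy group on the same carbon could read differently. Also open, on these data alone, is whether fluoro in place of nitro gives an equally small step on compound 2, which carries phenyl on the aromatic nitrogen.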